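Adding a Fluoro Beside the Chloro of Compound 3

The source may report more compounds than this note shows. Statements on the series, on what has been measured and on what is new or still open speak of the compounds shown alone.

Of the compounds shown here, three sharing one core have been measured so far. Compound 1, `Fc1cccc(Cn2nnc3c(Br)cccc32)c1`, gives 1.8 mL/min/g in an ADME assay on microsomes from liver (Homo sapiens) for metabolic stability, tested at 2.5 uM; on this read-out lower numbers stand for slow clearance and higher numbers for fast clearance. Compound 2, `Fc1ccc(Cn2nnc3c(Br)cccc32)cc1`, gives 1.2 mL/min/g, and compound 3, `Clc1ccc(Cn2nnc3c(Br)cccc32)cc1`, gives 0.6 mL/min/g. Compound 3 therefore has the lowest number of the three: compound 2 stands only a 2.0-fold lower number from compound 2 to compound 3 (0.30 log units; within the scatter), a gap within the usual scatter, while compound 1 stands beyond the scatter from it.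

The next compound, compound 4, `Fc1cc(Cn2nnc3c(Br)cccc32)ccc1Cl`, is the same as compound 3 except for one change: fluoro in place of hydrogen on an aromatic carbon. For the measured compounds named here, the single measured step that bears on this, a halogen swap on the same ring, was a 2.0-fold lower number from compound 2 to compound 3 (0.30 log units; within the scatter), and it did not leave the scatter. Nothing measured shows what a fluoro added to a hydrogen-bearing carbon does in this series, so the expectation rests on the small size of that one step. The step from compound 3 to compound 4 is expected to be a 1.2-fold lower number from compound 3 to compound 4 (0.08 log units; within the scatter), that is, no change beyond the scatter. Compound 4 is accordingly estimated at 0.5 mL/min/g, with a range from 0.25 mL/min/g to 1 mL/min/g in this assay.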

Compound 4, intrinsic clearance in a liver preparation (reported as CLH), per the amount of preparation that the assay uses: 0.4 mL/min/g
Beside the measured number, compound 4's estimate is 1.3-fold (0.10 log units) above it, within the range that was stated.
By their numbers in this assay, from the lowest: compounds 4, 3, 2 and 1 (each within the scatter of the next, the first and the last beyond it).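

In this assay, fluoro in place of hydrogen on an aromatic carbon, ortho to a chloro group and meta to a large group, gives a 1.5-fold lower number from compound 3 to compound 4 (0.18 log units; within the scatter), the first measured replacement of a hydrogen by fluoro in this series, and it stays within the scatter. Compound 4 can also be read as compound 1 with a chloro added, and that change gives a 4.5-fold lower number from compound 1 to compound 4 (0.65 log units; beyond the scatter), a modest step and the only single-place step shown so far that lies beyond the scatter, so adding the chloro moves the number measurably, while adding the fluoro to compound 3 does not. No measurement is at hand that explains either step.

The compounds shown leave open what a group other than a halogen would do on this same aromatic carbon, such as a methoxy, a nitrile or an amine. They also leave open how far the numbers depend on the bromo of the shared core, which all four compounds carry and which could be compared with a methyl or a plain hydrogen.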